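Methoxy for Methyl on the Aryl of Compound 2

A few compounds are considered here, and "the series" means these few. Any claim that something is new, unique, unknown or untested is made for them only; others in the source may bear on it.

Of the compounds shown here, three built on a shared core have been tested in a functional assay on the whole organism (strain Wistar) with Rattus norvegicus as the target, with a stated time of 15 days, at a dose of 10 mg/kg by the oral route; a higher number here means a stronger effect of the compound at the dose given, a lower number a weaker effect. Compound 1 `Cc1nc(COc2ccc(/C=C3\SC(=O)NC3=O)cc2)cs1` gives 19.2% in this assay. Compound 2 `Cc1ccc(-c2nnc(SCCOc3ccc(/C=C4\SC(=O)NC4=O)cc3)[nH]2)cc1` gives 21.7%, and compound 3 `O=C1NC(=O)/C(=C/c2ccc(OCCSc3nnc(-c4ccccc4[N+](=O)[O-])[nH]3)cc2)S1` gives 20.9%. Of the three numbers, that of compound 2 is nominally the highest, yet the step of a number 0.8 percentage points lower from compound 2 to compound 3 (within the scatter) lies within the usual scatter, and the value of compound 1 sits within the scatter of the value of compound 2 as well, so none of the three stands apart from the others.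

Compound 4 `COc1ccc(-c2nnc(SCCOc3ccc(/C=C4\SC(=O)NC4=O)cc3)[nH]2)cc1` has not yet been measured. Against compound 2 it differs in a single place: methoxy in place of methyl on an aromatic carbon. Among the measured compounds shown here, the only measured step that touches the same aryl group is a number 0.8 percentage points lower from compound 2 to compound 3 (within the scatter), where a larger exchange on that ring left the read-out essentially where it was. For the measured compounds named here, the exchange of methyl for methoxy is a smaller one, and nothing among the measured compounds points toward either direction. The step of a number 0.7 percentage points lower from compound 2 to compound 4 (within the scatter) is therefore expected to be none beyond the scatter. Compound 4 is expected to give 21% in this assay, within a range from 13% to 29%.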

Compound 4, a percentage reported as activity, at one dose (the size of the read-out at that dose, not a potency): 42.6%
Compound 4: middle estimate off by 21.6 percentage points, on the low side; measured number above the stated range.
By their numbers in this assay, from the lowest: compounds 1, 3 and 2 (each within the scatter of the next); then compound 4.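

Among the compounds shown here, until this result the aryl group of the shared core looked indifferent in this assay, given a number 0.8 percentage points lower from compound 2 to compound 3 (within the scatter) even though that exchange was a large one. The step of a number 20.9 percentage points higher from compound 2 to compound 4 (beyond the scatter) shows that this position does respond, and that the exchange of methyl for methoxy on an aromatic carbon, para to a large group, can move the read-out beyond the scatter while adding only one oxygen and one hydrogen-bond acceptor. The step of a number 21.7 percentage points higher from compound 3 to compound 4 (beyond the scatter) gives the same picture from the 2-nitrophenyl compound, so that the aryl groups of compound 2 and compound 3 remain level with each other while the 4-methoxyphenyl group of compound 4 stands apart from both.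

As far as these compounds go, whether an ethoxy, a hydroxyl or a dimethylamino group in the same place would raise the read-out further or lose the gain remains open. The read-out comes from one dose, so how compound 4 behaves at other doses also remains open, and nothing shown here accounts for the difference that the methoxy group makes.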